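Pyridazinone and pyridinone amides against MCF7 cell growth

The source may report more compounds than this note shows. Statements on the series, on what has been measured and on what is new or still open speak of the compounds shown alone.

Measured compounds:
Compound 1 `COc1ccc(-n2ccc(=O)c(C(=O)Nc3ccc(Oc4ccnc5c4ccn5C)cc3)n2)cc1`: > 60000 nM
Compound 2 `Cn1ccc2c(Oc3ccc(NC(=O)c4nn(-c5ccc(Cl)c(C(F)(F)F)c5)ccc4=O)cc3F)ccnc21`: 18400 nM
Compound 3 `Cc1cc(=O)n(-c2ccc(F)cc2)nc1C(=O)Nc1ccc(Oc2ncnc3[nH]ccc23)cc1`: 4800 nM

The three compounds were tested in a functional assay on MCF7 cells (Homo sapiens) for cytotoxicity, read by MTT assay, with a stated time of 72 h; a higher number here means a weaker inhibitor, a lower number a stronger inhibitor. Compound 1 gives only a limit, > 60000 nM, and no number; one of the three values sits at this limit (the limit of > 60000 nM in this assay, at which 1 of the 3 values shown sits). Compound 2 gives 18400 nM. Compound 3 gives 4800 nM, the lowest of the two numbers shown, and the gap to compound 2 lies beyond the usual scatter.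

Compound 4 `Cc1cc(=O)n(-c2cccc(C(F)(F)F)c2)nc1C(=O)Nc1ccc(Oc2ncnc3[nH]ccc23)cc1` has not yet been measured in this assay. It differs from compound 3 in one place: 3-(trifluoromethyl)phenyl in place of 4-fluorophenyl on an aromatic nitrogen, with 3-(trifluoromethyl)phenyl in place of 4-fluorophenyl on an aromatic nitrogen. Going by the values given here, no step between measured compounds covers this exchange, so the author expects a step of modest size, not clearly beyond the scatter, in either direction. For compound 4 the estimate is 4000 nM, between 1500 nM and 12000 nM, which is the expected step of a 1.2-fold lower number from compound 3 to compound 4 (0.08 log units; within the scatter).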

Compound 4, half-maximal inhibitory concentration: 4560 nM
Estimate against measurement, compound 4: 1.1-fold (0.06 log units) below; measured number inside the range.
By their numbers in this assay, from the lowest: compounds 4 and 3 (each within the scatter of the next); then compound 2. At a limit, above all of these: compound 1.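

In this assay, placing 3-(trifluoromethyl)phenyl instead of 4-fluorophenyl on the aromatic nitrogen gives a 1.1-fold lower number from compound 3 to compound 4 (0.02 log units; within the scatter). Going by these compounds alone, this is the first single exchange at this position, and it shows that going to a group with more heavy atoms, with a different substituent on the phenyl ring, does not separate the two compounds in this cell read-out. Nothing measured here bears on why the values stay so close.

Within the data shown here, the pair covers only two halogen-bearing phenyl groups, so it remains open how this position would respond to an amine or a carboxylic acid on that phenyl ring, or to a saturated ring such as cyclohexyl in its place. One exchange on one core also cannot show whether the same result would hold on the core of compound 1.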